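The source may report more compounds than this note shows. Statements on the series, on what has been measured and on what is new or still open speak of the compounds shown alone.

Compound 1, `O=S(=O)(Nc1ccc(-c2nc3ccccc3o2)cc1)c1ccccc1F`, gives in an assay on cells for inhibition of HSP60/HSP10 (Homo sapiens), with a stated time of 60 min (a lower number here means a stronger inhibitor, a higher number a weaker inhibitor), only the limit > 100000 nM, which is a limit of the measurement and not a number.
Compound 2, `O=S(=O)(Nc1ccc(-c2nc3ccccc3o2)cc1)c1ccc(C(F)(F)F)cc1`, gives in this assay the value 50000 nM.

Within the data shown here, compound 2 thus holds the only real number measured so far; the other result is a limit, as the limit of > 100000 nM in this assay, at which 1 of the 2 values shown sits, shows. Among the measured compounds shown here, compounds 1 and 2 differ in more than one place, so no single step between them can be read from their two values. Compound 3, `COc1ccc(S(=O)(=O)Nc2ccc(-c3nc4ccccc4o3)cc2)cc1`, is the next to be measured. It differs from compound 2 by methoxy in place of trifluoromethyl on an aromatic carbon, while everything else in compound 2 is kept. For the measured compounds named here, since no measured step exists between any pair here, nothing shows how large an effect such an exchange has in this assay; only weak inhibition has been seen, so a small shift in either direction, or none beyond the scatter, is the most that can be expected. The expected step is a 1.2-fold higher number from compound 2 to compound 3 (0.08 log units; within the scatter). Compound 3 is estimated at 60000 nM, between 20000 nM and 200000 nM, with a real chance that only a limit is reported.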

Compound 3, half-maximal inhibitory concentration: > 100000 nM
Compound 3: no number, only a limit (the forecaster's own chance of this, stated with the estimate: 40%); middle value at least 1.6-fold (0.22 log units) from the limit.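

Methoxy in place of trifluoromethyl on this aromatic carbon, para to a large group, gives the first step that can be read in this assay, namely an at least 2.0-fold higher number from compound 2 to compound 3 (0.30 log units; that floor lies within the scatter), and it is the first look at what an exchange at this place does. As far as these compounds go, compound 3 gives only a limit and not a number, so the true size of this step stays unknown: it could be no larger than the usual scatter, or it could be much larger. The step between compound 1 and compound 3 cannot be read, and a result of this kind marks the edge of what the measurement can show, where most of these compounds now sit: the limit of > 100000 nM in this assay, at which 2 of the 3 values shown sit.

Still open, from the compounds shown here alone, is whether another group on this aromatic carbon, such as an amine, a carboxylic acid or a nitrile, would give a clearly lower number than compound 2 gives with 50000 nM. Also open, going by these compounds, is whether trifluoromethyl would give a different result elsewhere on the same ring, or with a change in the shared core.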